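The source may report more compounds than this note shows. Statements on the series, on what has been measured and on what is new or still open speak of the compounds shown alone.

Among the measured compounds shown here, in a functional assay on NCI/ADR-RES cells (Homo sapiens) for cytotoxicity (a higher number here means a weaker inhibitor of growth, a lower number a stronger inhibitor of growth), only two compounds have numbers so far. Compound 1 `COc1ccc(NS(=O)(=O)c2c(F)c(F)c(F)c(F)c2Br)cc1` gives 160 nM and stands highest of the two, which makes it the weaker inhibitor of growth. Compound 2 `COc1ccc(NS(=O)(=O)c2c(F)c(Cl)c(F)c(Cl)c2F)cc1` gives 58 nM and the gap between the two lies beyond the usual scatter.

Compound 3 `COc1ccc(NS(=O)(=O)c2c(F)c(F)c(F)c(F)c2F)cc1` has not yet been measured in this assay and differs from compound 1 by fluoro in place of bromo on an aromatic carbon. For the measured compounds named here, no measured pair isolates this change, so the size of the step has no direct support. Going by the values given here, the only lower reference is compound 2 at 58 nM and a moderate move toward a lower number is therefore expected, although a result within the scatter of compound 1 remains possible. The estimated change is a 2.3-fold lower number from compound 1 to compound 3 (0.36 log units; beyond the scatter) and it points toward stronger growth inhibition. For compound 3 the expected value is 70 nM with an estimated range from 25 nM to 190 nM.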

Compound 3, concentration for 50% growth inhibition: 58 nM
For compound 3 the middle estimate is 1.2-fold (0.08 log units) above the measured one; the measured number falls inside the stated range.
By their numbers in this assay, from the lowest: compounds 2 and 3 (each within the scatter of the next); then compound 1.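

In this assay, among the compounds shown here, fluoro in place of bromo on an aromatic carbon gives a 2.8-fold lower number from compound 1 to compound 3 (0.44 log units; beyond the scatter) at a place that is ortho to a fluoro group and ortho to a large group, and this is the first direct reading of a single change. The step lies beyond the scatter, so the identity of the halogen at this place does register in growth inhibition, with compound 3 the stronger inhibitor of growth of this pair. No measured information available here bears on the reason for this step.

The compounds shown leave open how chloro, iodo, methyl or nitrile at this same place would read against compound 1 and compound 3, and so whether the two halogens mark the ends of a wider trend or only one pair. Also open, going by these compounds, is whether this exchange gives a step of similar size in a compound where the methoxy group of the shared core gives way to a hydroxyl or an amine.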